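The source may report more compounds than this note shows. Statements on the series, on what has been measured and on what is new or still open speak of the compounds shown alone.

Measured in a functional assay on A549 cells (Homo sapiens) for antiproliferative activity, read by MTT assay, with a stated time of 24 h; a lower number here means a stronger inhibitor, a higher number a weaker inhibitor:
- compound 1 `Cc1cccc(NNC(=O)c2ccccc2NS(=O)(=O)c2cnc(O)nc2O)c1`: > 20000 nM (a limit)
- compound 2 `O=C(NNC(=O)c1ccccc1Cl)c1ccc(NS(=O)(=O)c2cnc(O)nc2O)cc1`: 1900 nM
- compound 3 `O=C(NNC(=O)c1ccccc1F)c1ccc(NS(=O)(=O)c2cnc(O)nc2O)cc1`: 7610 nM

Compound 1 gives no number, only a limit: the limit of > 20000 nM in this assay, at which 1 of the 3 values shown sits.

Compound 4 `Cc1ccccc1C(=O)NNC(=O)c1ccccc1NS(=O)(=O)c1cnc(O)nc1O` is still unmeasured. It differs from compound 1 as follows: (2-methylphenyl)carbonyl in place of 3-methylphenyl on an amine nitrogen. In words, (2-methylphenyl)carbonyl stands in place of 3-methylphenyl on an amine nitrogen.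

Among the compounds with values here, only one measured step exists, a 4.0-fold higher number from compound 2 to compound 3 (0.60 log units; beyond the scatter). It is a fluoro in place of chloro change, so it does not test this replacement directly. It does show a modest move beyond the scatter from one small change.

The closest guide is that compound 2 at 1900 nM and compound 3 at 7610 nM also carry a substituted phenylcarbonyl group on that nitrogen, although their cores are not identical to that of compound 1. On that basis, a modest step towards a lower number is expected in this assay, and a result at the limit remains possible.

The estimated step is an at least 2.2-fold lower number from compound 1 to compound 4 (0.34 log units; beyond the scatter).

For compound 4 the expected value is 9000 nM, with an estimated range of 2500 nM to 30000 nM.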

Compound 4, half-maximal inhibitory concentration: 5450 nM
For compound 4 the middle estimate is 1.7-fold (0.22 log units) above the measured one; the range from low to high includes it.
By their numbers in this assay, from the lowest: compound 2; then compounds 4 and 3 (each within the scatter of the next). At a limit, above all of these: compound 1.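

In this assay, putting (2-methylphenyl)carbonyl in place of 3-methylphenyl on the amine nitrogen gives an at least 3.6-fold lower number from compound 1 to compound 4 (0.56 log units; beyond the scatter), the first step read at this position on this core. As far as these compounds go, compound 1 stands at a limit and not at a number, so the true size of the step remains unknown and this figure is only its lower bound: the limit of > 20000 nM in this assay, at which 1 of the 4 values shown sits. The change therefore shows that this nitrogen is not indifferent to its substituent, and that a group carrying a carbonyl there can bring the core to a measurable value.

From the compounds shown here alone, the change adds the carbonyl and alters the methyl's ring position at once, so the share of each stays open; (3-methylphenyl)carbonyl on the same nitrogen would separate them. Also open, going by these compounds, is whether the aromatic ring is needed on that carbonyl, which an acetyl group would test.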